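The source may report more compounds than this note shows. Statements on the series, on what has been measured and on what is new or still open speak of the compounds shown alone.

Compound 1 `OCc1ccc(-c2nn(Cc3cncnc3)c3ccccc23)o1` gives 3200 nM in a functional assay (aorta) with Oryctolagus cuniculus as the target; on this read-out higher numbers stand for weaker inhibition and lower numbers for stronger inhibition.
Compound 2 `CCc1c[nH]c(-c2nn(Cc3ccccc3F)c3ncccc23)n1` gives 600 nM in this assay.
Compound 3 `CCCCc1cnc(-c2nn(Cc3ccccc3F)c3ncccc23)nc1N` gives 218000 nM in this assay.

Compound 3 stands highest of the three numbers in this assay. Compound 1 is nearest to it, with a much lower number, and compound 2 is furthest, lower still; both gaps lie well beyond the usual scatter, so compound 3 is the weakest inhibitor of the three measured. Among the measured compounds shown here, compound 2 and compound 3 carry the same substituent on the core nitrogen, yet the ring attached to the shared core differs, and no pair among the three measured compounds differs in one place only, so no step can be read off directly.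

Compound 4 `CCCS(=O)(=O)c1cnc(-c2nn(Cc3ccccc3F)c3ncccc23)nc1N` has not been measured in this assay. It differs from compound 3 in one place: propylsulfonyl in place of butyl on an aromatic carbon. For the measured compounds named here, no measured pair shows what this exchange does in this assay; the expectation rests on the standing of compound 3 alone. Compound 3 sits far above the others, and a downward step, beyond the scatter, is expected a 2.7-fold lower number from compound 3 to compound 4 (0.44 log units; beyond the scatter). The step is not expected to bring compound 4 near compound 2. For compound 4 the expected value is 80000 nM, with a range from 10000 nM to 300000 nM.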

Compound 4, half-maximal inhibitory concentration: 378000 nM
Compound 4: the middle estimate sits 4.7-fold (0.67 log units) below what was measured; measured number above the stated range.
By their numbers in this assay, from the lowest: compound 2; then compound 1; then compounds 3 and 4 (each within the scatter of the next).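

In this assay, among the compounds shown here, propylsulfonyl in place of butyl on the aromatic carbon gives a 1.7-fold higher number from compound 3 to compound 4 (0.24 log units; within the scatter), the only one-place comparison available so far. At this position, ortho to an amino group and two atoms from the ring nitrogen, the read-out therefore does not separate a four-carbon chain without hydrogen-bond acceptors from a sulfur-containing group with 2 hydrogen-bond acceptors. Nothing on hand bears on why compound 3 and compound 4 cannot be told apart here.

Going by these compounds, whether a carboxylic acid, a primary amine, a methylsulfonyl group or a longer chain at this carbon would separate from compound 3 remains open, as does the reading with a hydrogen in place of the amino group. Steps linking compound 3 or compound 4 to compound 1 or compound 2 cannot be read, since those compounds differ in more than one place, so the reach of this single exchange beyond the pair remains unknown.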